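The compounds below may be only part of what the source reports. "The series", "measured", "known", "first", "only" and "open" are said of these compounds alone.

Measured compounds in a functional assay on the whole organism (Tail, strain ICR) with Mus musculus as the target, in the tail flick test, with a stated time of 30 min, at a dose of 25 umol/kg by the oral route; on this read-out higher numbers stand for a stronger effect at the one dose given and lower numbers for a weaker effect:
compound 1 `O=C(O)[C@@H]1CCCN1C(=O)CN(c1nc(Cl)nc2[nH]cnc12)C1CC1`: 31.5%
compound 2 `N=C(N)NCCC[C@H](NC(=O)CN(c1ncnc2c1ncn2C1CCCCO1)C1CC1)C(=O)OCc1ccccc1`: 34.3%
compound 3 `O=C(CN(c1ncnc2c1ncn2C1CCCCO1)C1CC1)N[C@@H](CO)C(=O)OCc1ccccc1`: 27.8%

Compound 3 sits at the low end of the three numbers in this assay, though its gaps to compound 1 and to compound 2 both lie within the scatter; the three values are not separated.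

Compound 4 `CC(C)[C@H](NC(=O)CN(c1ncnc2c1ncn2C1CCCCO1)C1CC1)C(=O)OCc1ccccc1` differs from compound 3 by isopropyl in place of hydroxymethyl on a saturated chain carbon bound to an amide-type nitrogen and a carbonyl carbon. Among the compounds with values here, the one step that bears on this position is a number 6.5 percentage points lower from compound 2 to compound 3 (within the scatter), a swap at the same saturated chain carbon that stayed within the scatter. On that basis no step beyond the scatter is expected in this assay, in either direction.

The expected step is a number 2.2 percentage points higher from compound 3 to compound 4 (within the scatter). Compound 4 is estimated at 30%, with a range from 20% to 42%.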

Compound 4, a percentage reported as activity, at one dose (the size of the read-out at that dose, not a potency): 21.8%
For compound 4 the middle estimate is 8.2 percentage points above the measured one, and the stated range covers the measured number.
By their numbers in this assay, from the lowest: compounds 4, 3, 1 and 2 (each within the scatter of the next, the first and the last beyond it).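

Isopropyl in place of hydroxymethyl on this saturated chain carbon gives a number 6 percentage points lower from compound 3 to compound 4 (within the scatter) in this assay and so leaves the two compounds unseparated. Within the data shown here, the wider comparison gives a number 12.5 percentage points lower from compound 2 to compound 4 (beyond the scatter) and is the first step at this carbon to pass beyond the scatter, which shows that the group held here can move the read-out at the one dose given. Nothing available accounts for that step.

From the compounds shown here alone, how an amine or a carboxylic acid on this carbon would read remains open. So does the effect of a longer chain without the nitrogen atoms of compound 2.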